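The source may hold more compounds than are shown below. What is called first, only, known or untested is meant among the compounds shown, and "the series" means these compounds.

Measured so far:
- compound 1, `CCn1ccc2cc(C(O)c3ccc(OC)c(OC)c3OC)ccc21`: > 10000 nM
- compound 2, `COc1ccc(Cc2cc(OC)c(OC)c(OC)c2)cc1[N+](=O)[O-]`: 32 nM
- compound 3, `COc1ccc(C(=O)c2ccc3ccccc3c2)c(OC)c1OC`: 3300 nM

In a functional assay on HL-60 cells (Homo sapiens) for cytotoxicity, read by XTT assay, with a stated time of 72 h (a higher number here means a weaker inhibitor, a lower number a stronger inhibitor), compound 2 gives 32 nM, the lowest of the two numbers in hand. Compound 3 gives 3300 nM, a gap from compound 2 that lies beyond the scatter. Compound 1 returns only > 10000 nM, a limit of the assay and not a number; this is the case described as the limit of > 10000 nM in this assay, at which 1 of the 3 values shown sits. Going by the values given here, no pair of measured compounds differs in one place, so no single step is available for direct comparison.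

Compound 4, `COc1ccc(Cc2cc(OC)c(OC)c(OC)c2)cc1N`, is not yet measured and is derived from compound 2 by one change: amino in place of nitro on an aromatic carbon. The nitro group is thus exchanged for an amino group at the same aromatic carbon, ortho to the methoxy group and meta to the large group, with the rest of compound 2 kept intact.

Among the compounds with values here, with no measured step of this kind to draw on, the expectation for compound 4 in this assay is a step from compound 2 of modest size, if any, likely toward a lower number; the estimated step is a 1.6-fold lower number from compound 2 to compound 4 (0.20 log units; within the scatter). Compound 4 is estimated at 20 nM, within a range of 5 nM to 100 nM.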

Compound 4, half-maximal inhibitory concentration: 29 nM
Compound 4: the middle estimate sits 1.5-fold (0.16 log units) below what was measured; measured number inside the range.
By their numbers in this assay, from the lowest: compounds 4 and 2 (each within the scatter of the next); then compound 3. At a limit, above all of these: compound 1.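

Going by these compounds alone, this is the first step between compounds that differ in one place, and in this assay it reads a 1.1-fold lower number from compound 2 to compound 4 (0.04 log units; within the scatter). At this aromatic carbon, ortho to a methoxy group and meta to a large group, nitro and amino cannot be told apart in this read-out, even though the two groups differ in heavy atoms, hydrogen-bond donors and hydrogen-bond acceptors. No measured finding at hand bears on this result.

From the compounds shown here alone, whether the same holds for other groups at this carbon, such as hydroxyl, fluoro, methyl or acetamide, stays open, since a single exchange on a single core gives no trend across substituents. Going by these compounds, compound 1 and compound 3 each differ from compound 2 in more than one place, so they say nothing about this position, and it also stays open whether the amino and nitro groups would remain indistinguishable on either of those cores or in cells other than the one line tested here.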